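The compounds below may be only part of what the source reports. "The series", "measured", "known", "first", "only" and "open" are said of these compounds alone.

Measured in an ADME assay on microsomes from liver (Homo sapiens) for metabolic stability, with a stated time of 10 min (a higher number here means that more of the compound is left, a lower number that less of the compound is left), so far:
compound 1 `O=C(N1CCOCC1)N1CC[C@](c2ccc(C(OCc3c(F)cccc3F)(C(F)(F)F)C(F)(F)F)cc2)(S(=O)(=O)c2ccc(F)cc2)C1` gives 3%
compound 2 `O=C(O)[C@H]1CC[C@H](C(=O)N2CC[C@](c3ccc(C(OCc4c(F)cccc4Cl)(C(F)(F)F)C(F)(F)F)cc3)(S(=O)(=O)c3ccc(F)cc3)C2)CC1` gives 100%

Compound 2 at 100% is the higher of the two, beyond the scatter from compound 1. Compound 3 `O=C(O)[C@H]1CC[C@H](C(=O)N2CC[C@](c3ccc(C(OCC4CCCCC4)(C(F)(F)F)C(F)(F)F)cc3)(S(=O)(=O)c3ccc(F)cc3)C2)CC1` differs from compound 2 by cyclohexyl in place of 2-chloro-6-fluorophenyl on a saturated chain carbon bound to an oxygen on a saturated carbon in one place, on a saturated chain carbon bound to an oxygen on a saturated carbon. Among the compounds with values here, no measured pair shows this change alone. With compound 2 at 100% the read-out has room only downward. The step expected in this assay is a moderate fall, a number 25 percentage points lower from compound 2 to compound 3 (beyond the scatter) by this estimate. For compound 3 the expected value is 75% within an estimated range of 40% to 100% for now.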

Compound 3, percent of the compound remaining: 92%
Estimate against measurement, compound 3: 17 percentage points below; the range from low to high includes it.
By their numbers in this assay, from the lowest: compound 1; then compounds 3 and 2 (each within the scatter of the next).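

In this assay, cyclohexyl in place of 2-chloro-6-fluorophenyl on a saturated chain carbon bound to an oxygen on a saturated carbon gives a number 8 percentage points lower from compound 2 to compound 3 (within the scatter). In this pair, the read-out therefore does not depend on an aromatic ring or on the chlorine and fluorine at this position. No evidence on the cause of this result is at hand.

From the compounds shown here alone, it remains open whether a longer alkyl chain or an amine at this position would leave the read-out unchanged. Going by these compounds, compound 1 differs from compound 2 and compound 3 in more than one place, so the source of its low value also remains open.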